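The compounds below may be only part of what the source reports. "The series", "measured", "known", "first", "only" and "open" are said of these compounds alone.

Measured in an ADME assay on Huh7.5.1 cells (Homo sapiens) for cytotoxicity, read by WST assay, with a stated time of 48 h; a lower number here means that less compound is tolerated, a higher number that more compound is tolerated:

- compound 1 `Cc1c(-c2ccc(Cc3ccc(OC(F)F)cc3)cc2)[nH]c2cccc(F)c2c1=O` gives > 5000 nM
- compound 2 `Cc1c(-c2ccc(Oc3ccc(SC(F)(F)F)cc3)c(F)c2)[nH]c2cccc(F)c2c1=O` gives > 10000 nM
- compound 3 `Cc1c(-c2ccc(Oc3ccc(N4CCCC4)cc3)c(F)c2)[nH]c2cccc(F)c2c1=O` gives > 10000 nM

All three readings are limits of the assay, not numbers. Compound 3 stands only at its limit of > 10000 nM, which it shares with compound 2, as the limit of > 10000 nM in this assay, at which 2 of the 3 values shown sit, shows. Compound 1 sits at a separate limit, (the limit of > 5000 nM in this assay, at which 1 of the 3 values shown sits).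

Compound 4 `Cc1c(-c2ccc(Oc3ccc(N(C)C)cc3)c(F)c2)[nH]c2cccc(F)c2c1=O` differs from compound 3 at one place: dimethylamino in place of pyrrolidin-1-yl on an aromatic carbon. This puts dimethylamino in place of pyrrolidin-1-yl on an aromatic carbon, para to a large group.

Within the data shown here, the one measured step at this place is a step that the two limits leave unreadable from compound 2 to compound 3. It gives no size to carry over, and neither of its two compounds reached a number. With compound 3 at > 10000 nM, no change beyond the scatter is expected, and compound 4 may well return another limit. The expected change is a number no higher from compound 3 to compound 4 (the limit leaves the size open). The estimated value for compound 4 is 10000 nM, expected to lie between 5000 nM and 20000 nM.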

Compound 4, half-maximal cytotoxic concentration: > 10000 nM
Compound 4 gave a limit, no number; the forecaster's own chance of this, stated with the estimate: 80%; the middle value sits exactly at the limit.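

In this assay compound 4 gives > 10000 nM, a limit of the assay and not a number. The steps among compound 2, compound 3 and compound 4 cannot be read. The compounds shown leave open whether swapping pyrrolidin-1-yl for dimethylamino changes tolerance at all.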